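A few compounds are considered here, and "the series" means these few. Any claim that something is new, unique, unknown or untested is made for them only; others in the source may bear on it.

Working notes on the series. In a functional assay on A549 cells (Homo sapiens) for antiproliferative activity, read by MTT assay, with a stated time of 48 h (on this read-out lower numbers stand for stronger inhibition and higher numbers for weaker inhibition), compound 1 (`COc1ccc(C(=O)c2ccc3c(c2)C=CC(C)(C)O3)c(NC(=O)CBr)c1`) gives 1980 nM. That sits level, within the scatter, with compound 3 (`CNCC(=O)Nc1cc(OC)ccc1C(=O)c1ccc(OC)c2c1C=CC(C)(C)O2`) at 1370 nM, while compound 2 (`COc1ccc(C(=O)c2ccc(OC)c3c2OC(C)(C)C=C3)c(NC(=O)CN)c1`) gives 270 nM, a lower number than that of compound 1, with the gap between the two lying beyond the scatter.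

Compound 4 (`CNCC(=O)Nc1cc(OC)ccc1C(=O)c1ccc2c(c1)C=CC(C)(C)O2`) has not yet been measured. It keeps the core of compound 1 and differs in one place: methylamino in place of bromo on a saturated chain carbon bound to a carbonyl carbon.

Within the data shown here, no measured pair isolates this change, so any expectation for this assay is indirect. The closest guide is compound 3, which also carries methylamino on that chain and gives 1370 nM. On that basis, no step beyond the scatter is expected, and the estimated change is small: a 1.3-fold lower number from compound 1 to compound 4 (0.12 log units; within the scatter).

For compound 4 the expected value is 1500 nM, with an estimated range of 600 nM to 3500 nM.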

Compound 4, half-maximal inhibitory concentration: 800 nM
For compound 4 the middle estimate is 1.9-fold (0.27 log units) above the measured one, within the range that was stated.
By their numbers in this assay, from the lowest: compound 2; then compounds 4, 3 and 1 (each within the scatter of the next, the first and the last beyond it).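

Among these compounds, this is the first pair that isolates a change on this chain carbon. In this assay, methylamino in place of bromo gives a 2.5-fold lower number from compound 1 to compound 4 (0.39 log units; beyond the scatter), so the position does respond to the group it carries, and bromo is not needed to reach this level of activity on the core of compound 1. No measurement in hand bears on the reason for this step.

Still open, on these data alone, is whether the step belongs to methylamino specifically, or whether dimethylamino, a piperidine or a longer chain between the carbonyl carbon and the nitrogen would give a similar number on the same core. The compounds shown also leave open whether the same exchange would give a step of similar size on the core of compound 3.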